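The source may hold more compounds than are shown below. What is called first, only, known or untested is meant among the compounds shown, and "the series" means these compounds.

Compound 2, whose structure is `Cc1ccc(-n2nc(C(=O)Nc3ccc(Oc4ncnc5c4ccn5C)cc3)c(C)cc2=O)cc1`, carries a 4-methylphenyl group on an aromatic nitrogen of the shared core. In a functional assay on A549 cells (Homo sapiens) for cytotoxicity, read by MTT assay, with a stated time of 72 h (on this read-out higher numbers stand for weaker inhibition and lower numbers for stronger inhibition), compound 2 reached only the limit of the measurement, > 60000 nM, so no exact number is known for it. Its closest measured relative is compound 1, `Cc1cc(=O)n(-c2ccc(Br)cc2F)nc1C(=O)Nc1ccc(Oc2ncnc3c2ccn3C)cc1`, which bears a 4-bromo-2-fluorophenyl group in the same place; in this assay compound 1 gives 47300 nM. Among the compounds with values here, the one measured step, an at least 1.2-fold higher number from compound 1 to compound 2 (0.10 log units; that floor lies within the scatter), shows no change beyond the ordinary scatter, and its floor rests on the limit (the limit of > 60000 nM in this assay, at which 1 of the 2 values shown sits). Compound 3, `Cc1cc(=O)n(-c2ccccc2C(F)(F)F)nc1C(=O)Nc1ccc(Oc2ncnc3c2ccn3C)cc1`, differs from compound 2 by 2-(trifluoromethyl)phenyl in place of 4-methylphenyl on an aromatic nitrogen. Within the data shown here, both measured compounds sit in a very weak region, and the single step between them points in no clear direction, so compound 3 is expected to remain in that same region. The expected step of a number no higher from compound 2 to compound 3 (the limit leaves the size open) is therefore estimated to lie within the scatter, with a fair chance that compound 3 again returns only a limit. For compound 3 the estimate is 60000 nM, with a range from 30000 nM to 120000 nM.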

Compound 3, half-maximal inhibitory concentration: 5860 nM
Estimate against measurement, compound 3: 10-fold (1.01 log units) above; measured number outside the range, below it.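

The earlier pair left it unclear whether the group on this aromatic nitrogen mattered at all, but 2-(trifluoromethyl)phenyl now brings a clear change in this assay. Replacing 4-methylphenyl gives an at least 10-fold lower number from compound 2 to compound 3 (1.01 log units; beyond the scatter), and replacing 4-bromo-2-fluorophenyl gives an 8.1-fold lower number from compound 1 to compound 3 (0.91 log units; beyond the scatter), so compound 3 stands apart from both of the other compounds and this position can clearly influence the cytotoxicity read-out. The first of these steps has only a floor, and its full size stays unknown because one end of it is a limit and not an exact number: the limit of > 60000 nM in this assay, at which 1 of the 3 values shown sits.

Three compounds cannot show whether the stronger inhibition belongs to the trifluoromethyl group itself or to its place on the phenyl ring, and a 2-methylphenyl or 4-(trifluoromethyl)phenyl group in the same position would help to separate the two. On these data alone, it also remains open whether a phenyl ring carrying an amine or a carboxylic acid would extend this stronger inhibition or lose it.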